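Halogen swap on the benzamide of a shared thiazole series

This account rests on a few compounds, and the source may have more. Where it says the series, first, only, none or still open, it means among the compounds named here.

Measured compounds and values in an ADME assay on Vero cells (Chlorocebus sabaeus) for cytotoxicity, read by MTT assay, with a stated time of 72 h; a higher number here means that more compound is needed for the effect, a lower number that less compound is needed:
compound 1, `O=C(Nc1nc(-c2ccccn2)cs1)c1cccc(Cl)c1`: 7000 nM
compound 2, `O=C(Nc1nc(-c2ccccn2)cs1)c1cccc(F)c1`: 1200 nM
compound 3, `O=C(Nc1nc(-c2ccccn2)cs1)c1c(F)cccc1F`: 3200 nM

Compound 4, `O=C(Nc1nc(-c2ccccn2)cs1)c1c(F)cccc1Cl`, has not yet been measured in this assay.

From compound 2 to compound 1 the change is chloro in place of fluoro on an aromatic carbon, and in this assay this gave a 5.8-fold higher number from compound 2 to compound 1 (0.77 log units; beyond the scatter). From compound 3 to compound 4 the change is chloro in place of fluoro on an aromatic carbon. The two place lines are not the same word for word: in the first case the site is meta to a large group, in the second it is ortho to a large group and meta to a fluoro group, so the change is of the same kind, not the same. The difference between the core of compound 2 and the core of compound 3 is not broken down here; in this assay compound 3 gives 3200 nM against compound 2 at 1200 nM.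

Among the measured compounds shown here, the step from compound 3 to compound 4 in this assay is expected to be a 2.8-fold higher number from compound 3 to compound 4 (0.45 log units; beyond the scatter), smaller than the earlier one, because the single precedent a 5.8-fold higher number from compound 2 to compound 1 (0.77 log units; beyond the scatter) sits at a different place. For compound 4 the estimated value in this assay is 9000 nM, with a range from 4000 nM to 20000 nM.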

Compound 4, half-maximal effective concentration: 1300 nM
For compound 4 the middle estimate is 6.9-fold (0.84 log units) above the measured one; the whole stated range lies above it.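

In this assay, chloro in place of fluoro on an aromatic carbon gave a 2.5-fold lower number from compound 3 to compound 4 (0.39 log units; beyond the scatter), so the direction of the earlier step did not carry over to the second core: the same change on two cores in this assay, a 5.8-fold higher number (0.77 log units; beyond the scatter) from compound 2 to compound 1 and a 2.5-fold lower number (0.39 log units; beyond the scatter) from compound 3 to compound 4, 14-fold (1.16 log units) apart, beyond the scatter of two such steps

On these two steps, the change cannot be carried from one core to another in this series as a fixed shift, or even with a fixed sign. The steps do not show what lies behind the reversal, since the core and the site differ together, with the site in compound 4 ortho to a large group and meta to a fluoro group, and two steps give no rule for any further core.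

Open, on these data alone, is whether the step on the core of compound 3 depends on the remaining fluoro group, which a matched pair at the same site with hydrogen in its place could test. Also open is how a methyl, methoxy, trifluoromethyl or amine group on the same aromatic carbon would read in this assay, as the compounds shown carry only fluoro and chloro there.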